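The source may report more compounds than this note shows. Statements on the series, on what has been measured and on what is new or still open speak of the compounds shown alone.

Measured compounds:

compound 1 `Cc1cnc(C(=O)Nc2cc(F)cc3cccnc23)cn1` — 2100 nM in a functional assay on PANC-1 cells (Homo sapiens) for inhibition, read by MTT assay, with a stated time of 72 h; on this read-out lower numbers stand for stronger inhibition and higher numbers for weaker inhibition

compound 2 `COc1cc(NC(=O)c2cnc(C)cn2)c2ncccc2c1` — 800 nM in this assay

Within the data shown here, on the two numbers available, compound 2 stands lowest; its only neighbour is compound 1, and the single step known, a 2.6-fold lower number from compound 1 to compound 2 (0.42 log units; beyond the scatter), is a change at the aromatic carbon, not on the ether chain. Compound 3 `Cc1cnc(C(=O)Nc2cc(OCCNC(=O)OC(C)(C)C)cc3cccnc23)cn1` differs from compound 2 by ((tert-butoxycarbonyl)amino)methyl in place of hydrogen on a saturated chain carbon bound to an oxygen on an aromatic ring; read one bond further out, the methyl on the ether oxygen becomes a 2-((tert-butoxycarbonyl)amino)ethyl chain. Among the measured compounds shown here, no measured step touches that chain, so the methoxy-for-fluoro step gives no direct guide to the size or direction of this change; it only shows that the position tolerates variation. The expectation is therefore for no clear shift beyond the scatter, with a wide range to cover the untested chain: compound 3 is estimated at 1200 nM (range 400 nM to 4000 nM), i.e. an expected step of a 1.5-fold higher number from compound 2 to compound 3 (0.18 log units; within the scatter).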

Compound 3, half-maximal inhibitory concentration: 2170 nM
Beside the measured number, compound 3's estimate is 1.8-fold (0.26 log units) below it; the range from low to high includes it.
By their numbers in this assay, from the lowest: compound 2; then compounds 1 and 3 (each within the scatter of the next).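

In this assay, among these compounds, replacing the methyl on the ether oxygen with 2-((tert-butoxycarbonyl)amino)ethyl gives a 2.7-fold higher number from compound 2 to compound 3 (0.43 log units; beyond the scatter) and so provides the first reading on the ether chain, which the earlier step left untouched. The number therefore responds to change on this chain, and in the direction of weaker inhibition. Even so, an entering group of 9 heavy atoms with no ring moves it only modestly, and nothing measured for this series explains the step.

With a single chain compound, the step cannot be assigned to the ethyl linker or to the tert-butoxycarbonyl group. A free primary amine on the same ethyl chain, a carboxylic acid at its end, or a longer chain would help separate these contributions.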